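This account rests on a few compounds, and the source may have more. Where it says the series, first, only, none or still open, it means among the compounds named here.

Measured compounds:
compound 1 `CC1=CC[C@H](C(C)(C)NC(=S)N/N=C/c2ccccc2O)CC1` — 6400 nM
compound 2 `COc1cc(/C=N/NC(=S)NC(C)(C)[C@H]2CC=C(C)CC2)ccc1O` — 11700 nM
compound 3 `CC1=CC[C@H](C(C)(C)NC(=S)N/N=C/c2ccccc2[N+](=O)[O-])CC1` — 20200 nM

These three compounds share one core and differ only in the aromatic group attached to the carbon with a double bond to nitrogen. In a functional assay on U-251 cells (Homo sapiens) for inhibition, read by sulforhodamine B assay, with a stated time of 48 h (on this read-out lower numbers stand for stronger inhibition of growth and higher numbers for weaker inhibition of growth), compound 1 gives the lowest of the three numbers. Compound 2 sits close to it, within the usual scatter, so no order between compound 1 and compound 2 can be read from these two values. Compound 3 lies further off: a 3.2-fold higher number from compound 1 to compound 3 (0.50 log units; beyond the scatter). That single step is the only one available, and it shows that swapping the hydroxy on the aromatic ring for another group moved the number upward.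

Compound 4 `CC1=CC[C@H](C(C)(C)NC(=S)N/N=C/c2cccs2)CC1` has not yet been measured in this assay. It differs from compound 1 in one place: thiophen-2-yl in place of 2-hydroxyphenyl on a carbon with a double bond to nitrogen. Going by the values given here, the change is larger than the one between compound 1 and compound 3, since the whole ring is replaced and the hydroxy donor is lost rather than swapped. The step from compound 1 to compound 3 suggests that losing the hydroxy tends to push the number up, so a modestly higher number is expected for compound 4, in the direction of weaker growth inhibition: a 1.9-fold higher number from compound 1 to compound 4 (0.27 log units; within the scatter). Compound 4 is therefore estimated at 12000 nM, within a range from 5000 nM to 30000 nM.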

Compound 4, concentration for 50% growth inhibition: 13500 nM
Beside the measured number, compound 4's estimate is 1.1-fold (0.05 log units) below it; measured number inside the range.
By their numbers in this assay, from the lowest: compounds 1, 2, 4 and 3 (each within the scatter of the next, the first and the last beyond it).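

In this assay, thiophen-2-yl in place of 2-hydroxyphenyl on a carbon with a double bond to nitrogen gives a 2.1-fold higher number from compound 1 to compound 4 (0.32 log units; beyond the scatter) and so shows that this position also responds when the whole ring is exchanged, and not only when the group on the ring is changed. Together with the earlier step (a 3.2-fold higher number from compound 1 to compound 3 (0.50 log units; beyond the scatter)), this makes two replacements away from compound 1, and both raise the number, which means weaker inhibition of growth in these cells, although one keeps a six-membered ring and the other brings in a five-membered ring with sulfur. Nothing at hand explains why the number rises with this change.

The compounds shown leave open whether the rise goes with the loss of the hydroxy, with the change of ring, or with both together. A plain phenyl group, carrying no hydroxy on the same six-membered ring, would help to separate these two changes, and furan-2-yl, with oxygen in the ring in place of sulfur, would test how much the ring's hetero atom matters.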